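Cytotoxicity limits in a short anilinomethyl series

The compounds below may be only part of what the source reports. "The series", "measured", "known", "first", "only" and "open" are said of these compounds alone.

Working notes. Three members of one series have been run in an ADME assay on Vero 76 cells (Chlorocebus sabaeus) for cytotoxicity, read by MTT assay, with a stated time of 96 h; on this read-out higher numbers stand for lower toxicity in this test and lower numbers for higher toxicity in this test. Compound 1 `Cc1ccc(NCc2cn(-c3ccccc3)nc2-c2ccc(C)cc2)cc1` is the parent with methyl on both outer rings. In this assay compound 1 reads > 100000 nM, which is a limit of the assay and not a number. Compound 2 `Cc1ccc(NCc2cn(-c3ccccc3)nc2-c2ccccc2)cc1` drops one methyl; in this assay compound 2 reads > 100000 nM, again only a limit. Compound 3 `Cc1ccc(-c2nn(-c3ccccc3)cc2CNc2ccc(Cl)cc2)cc1` carries chloro where compound 1 carries methyl on the amine-bearing ring; in this assay compound 3 reads > 100000 nM, also a limit. The step that the two limits leave unreadable from compound 1 to compound 2 comes from hydrogen in place of methyl on an aromatic carbon, and the step that the two limits leave unreadable from compound 1 to compound 3 from chloro in place of methyl on an aromatic carbon; neither can be sized, since all three values sit at the limit of > 100000 nM in this assay, at which 3 of the 3 values shown sit.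

Compound 4 `Clc1ccc(NCc2cn(-c3ccccc3)nc2-c2ccccc2)cc1` is not yet measured. It differs from compound 3 by hydrogen in place of methyl on an aromatic carbon, the same change as that from compound 1 to compound 2, the place being identical word for word. The two cores differ by chloro in place of methyl on an aromatic carbon.

For compound 4 the step that the limit leaves unreadable from compound 3 to compound 4 is expected to stand beside a step that the two limits leave unreadable from compound 1 to compound 2, resting on compound 1 and compound 2 both sitting at the limit of > 100000 nM in this assay, at which 3 of the 3 values shown sit. Compound 4 is therefore expected to read about 150000 nM, with a range estimated from 60000 nM to 400000 nM, most likely returned as a limit rather than a number.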

Compound 4, half-maximal cytotoxic concentration: 65000 nM
The estimate for compound 4 lay 2.3-fold (0.36 log units) above the measured number, within the range that was stated.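

In this assay compound 4 gives 65000 nM, and the two steps into it can be given only as floors: an at least 1.5-fold lower number from compound 3 to compound 4 (0.18 log units; that floor lies within the scatter) for the change from 4-methylphenyl to phenyl, and an at least 1.5-fold lower number from compound 2 to compound 4 (0.18 log units; that floor lies within the scatter) for chloro in place of methyl. On these data alone, the matching step on the core of compound 1 and the other steps among the first three compounds cannot be read, so it stays unknown whether hydrogen in place of methyl has the same size on both cores, because the values there are limits and not numbers: the limit of > 100000 nM in this assay, at which 3 of the 4 values shown sit. Compound 4 thus shows that a number can be obtained in this series when chloro and phenyl occur together, but with both floors within the scatter, it shows neither that the change carries from one core to the other nor that it fails to carry.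

The compounds shown leave open how an amine, a carboxylic acid or a longer chain in place of the methyl or chloro would read in this assay. They also leave open whether any group other than chloro, methyl and hydrogen at this place would give a number rather than a limit, and so a step that can be sized on both cores.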